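The compounds below may be only part of what the source reports. "The series", "measured", "known", "first", "only" and "open" are said of these compounds alone.

Series notes. In an assay on cells for inhibition of HSP60/HSP10 (Homo sapiens), with a stated time of 60 min (a lower number here means a stronger inhibitor, a higher number a weaker inhibitor), compound 1 `O=S(=O)(Nc1ccc(-c2nc3ccccc3o2)cc1)c1ccc(Cl)c(C(F)(F)F)c1` gives 12000 nM. Compound 2 `Cc1ccc(S(=O)(=O)Nc2ccc(-c3nc4ccccc4o3)cc2)cc1` returns only a limit of the assay, > 100000 nM. Compound 3 `Cc1ccc(S(=O)(=O)Nc2ccc3oc(-c4ccccc4)nc3c2)cc1` likewise returns only a limit, > 100000 nM. Two of the three values shown therefore sit at the limit of > 100000 nM in this assay, at which 2 of the 3 values shown sit, so no number is known for compound 3 and no measured step between any two of these compounds exists. Compound 4 `COc1cccc(S(=O)(=O)Nc2ccc3oc(-c4ccccc4)nc3c2)c1` differs from compound 3 in one place: 3-methoxyphenyl in place of 4-methylphenyl on a sulfonyl sulfur. Among the compounds with values here, no measured step of this kind is available in this assay, so the change is taken as small, with no direction expected beyond the usual scatter. Compound 4 is expected at about 100000 nM in this assay, within 30000 nM to 300000 nM, most likely again a limit. The expected step from compound 3 to compound 4 is a number no higher from compound 3 to compound 4 (the limit leaves the size open).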

Compound 4, half-maximal inhibitory concentration: > 100000 nM
Compound 4 ended at the assay's limit; the forecaster's own chance of this, stated with the estimate: 75%; the middle value lies on the limit itself.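

Within the data shown here, compound 3 and compound 4 both give only a limit in this assay, so no step between them can be read: the limit of > 100000 nM in this assay, at which 3 of the 4 values shown sit. The compounds shown leave open whether 3-methoxyphenyl in place of 4-methylphenyl on a sulfonyl sulfur changes the read-out at all.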